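The source may report more compounds than this note shows. Statements on the series, on what has been measured and on what is new or still open speak of the compounds shown alone.

Compound 1 `COc1ccc(-c2cnc3nc(N)nc(N4CCN(C(=O)COc5ccccc5)CC4)c3n2)cc1OC` stands lowest of the three compounds measured in a functional assay on cells (T-cell, Homo sapiens) for inhibition (on this read-out higher numbers stand for weaker inhibition and lower numbers for stronger inhibition), where compound 1 gives 4 nM. Compound 2 `CCOc1nc(N)nc2ncc(-c3ccc(C(F)(F)F)cc3)nc12` in this assay gives 10000 nM, and compound 3 `CCOc1nc(N)nc2ncc(-c3cccc(OC)c3)nc12` gives 8300 nM; both gaps to compound 1 lie beyond the scatter. Compound 4 `COc1ccc(-c2cnc3nc(N)nc(N4CCN(Cc5c(Cl)cccc5Cl)CC4)c3n2)cc1OC` has not yet been measured. It differs from compound 1 in one place: 2,6-dichlorobenzyl in place of (phenoxymethyl)carbonyl on an amine nitrogen in a ring. Among the measured compounds shown here, no step between measured compounds covers a change of this kind, so the expectation for compound 4 rests on compound 1 alone. The change is expected to cost little, an estimated 2.0-fold higher number from compound 1 to compound 4 (0.30 log units; within the scatter), not beyond the scatter. Compound 4 is therefore expected to give 8 nM in this assay, within a range of 2 nM to 40 nM.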

Compound 4, half-maximal inhibitory concentration: 7600 nM
Compound 4: middle estimate off by 950-fold (2.98 log units), on the low side; measured number above the stated range.
By their numbers in this assay, from the lowest: compound 1; then compounds 4, 3 and 2 (each within the scatter of the next).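

In this assay, the group on this ring nitrogen proves decisive: 2,6-dichlorobenzyl in place of (phenoxymethyl)carbonyl produces a 1900-fold higher number from compound 1 to compound 4 (3.28 log units; beyond the scatter) on an unchanged core. The low number of compound 1 therefore does not hold for every group at this position. The swap also exchanges a group with hydrogen-bond acceptors for one with none, and nothing shown accounts for the loss. From the compounds shown here alone, it remains open whether the missing carbonyl or the added chlorines matter more. Plain benzyl or acetyl on the same nitrogen would help separate the two.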